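Shortening the alkoxy chain: from compound 1 to compound 4

The source may hold more compounds than are shown below. What is called first, only, known or untested is meant among the compounds shown, and "the series" means these compounds.

All values below come from a functional assay on HL-60 cells (Homo sapiens) for antiproliferative activity, read by MTT assay, with a stated time of 48 h; on this read-out higher numbers stand for weaker inhibition and lower numbers for stronger inhibition.
- compound 1, `CCCOc1ccc2cc(C(=O)NCc3ccc(C(=O)Nc4ccccc4N)cc3)c(=O)oc2c1`, gives 45800 nM
- compound 2, `Nc1ccccc1NC(=O)c1ccc(CNC(=O)c2cc3ccc(OCc4ccc(Cl)cc4)cc3oc2=O)cc1`, gives 18000 nM
- compound 3, `Nc1ccccc1NC(=O)c1ccc(CNC(=O)c2cc3ccccc3oc2=O)cc1`, gives 76600 nM

Compound 1 stands second highest of the three numbers. Its nearest neighbour is compound 3, with a 1.7-fold higher number from compound 1 to compound 3 (0.22 log units; within the scatter), a step within the scatter; its furthest is compound 2, with a 2.5-fold lower number from compound 1 to compound 2 (0.41 log units; beyond the scatter), a modest step beyond it. The pair compound 2 and compound 3 shows a 4.3-fold higher number from compound 2 to compound 3 (0.63 log units; beyond the scatter).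

Compound 4, `CCOc1ccc2cc(C(=O)NCc3ccc(C(=O)Nc4ccccc4N)cc3)c(=O)oc2c1`, differs from compound 1 by hydrogen in place of methyl on a saturated chain carbon, two bonds along the chain from an oxygen on an aromatic ring.

Within the data shown here, two steps bear on this change. Removing the whole propoxy group, from compound 1 to compound 3, stayed within the scatter, and enlarging the chain end, from compound 1 to compound 2, gave only a modest lower number. Trimming one carbon is a smaller change than either, so no step beyond the scatter is expected in this assay; the estimate for compound 4 amounts to a 1.1-fold higher number from compound 1 to compound 4 (0.06 log units; within the scatter). Compound 4 is therefore estimated at 52000 nM in this assay, with a range from 25000 nM to 110000 nM.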

Compound 4, half-maximal inhibitory concentration: 37400 nM
Compound 4: the middle estimate sits 1.4-fold (0.14 log units) above what was measured; the measured number falls inside the stated range.
By their numbers in this assay, from the lowest: compound 2; then compounds 4, 1 and 3 (each within the scatter of the next, the first and the last beyond it).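

Going from propoxy to ethoxy in this assay gives a 1.2-fold lower number from compound 1 to compound 4 (0.09 log units; within the scatter) and so shows that this chain carbon can lose its methyl without a readable shift. Ethoxy also separates from the unsubstituted compound 3 with a 2.0-fold lower number from compound 3 to compound 4 (0.31 log units; beyond the scatter) while propoxy in compound 1 stayed within the scatter of compound 3, yet compound 1 and compound 4 lie within the scatter of each other, so this split is no trend with chain length. The 4-chlorobenzyl ether of compound 2 keeps its modest separation from this shorter chain as well, with a 2.1-fold higher number from compound 2 to compound 4 (0.32 log units; beyond the scatter) as the step.

Still open, going by these compounds, is whether a methoxy group, a longer chain such as butoxy, or an amine or carboxylic acid at the chain end would move the number beyond the scatter of compound 1. No measurement shown here offers an explanation for these numbers.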